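Triazole-linked series: cytotoxicity limits and a pending analog

The compounds below may be only part of what the source reports. "The series", "measured", "known", "first", "only" and "open" are said of these compounds alone.

Compound 1 `Cc1c(O)ccc2c1[C@H](Cn1cc(-c3ccc(F)cc3)nn1)[C@@]13CC(=O)[C@@](C)(CC[C@@H]21)C3`. In a functional assay on A549 cells (Homo sapiens) for cytotoxicity, read by MTT assay, with a stated time of 4 days (on this read-out higher numbers stand for weaker inhibition and lower numbers for stronger inhibition), compound 1 gives only a limit of the assay, > 20000 nM.
Compound 2 `Cc1c(O)ccc2c1[C@H](Cn1cc(-c3ccc(C(F)(F)F)cc3)nn1)[C@@]13CC(=O)[C@@](C)(CC[C@@H]21)C3`. In this assay compound 2 likewise gives only a limit, > 20000 nM.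
Compound 3 `C=C1C[C@]23C[C@@]1(O)CC[C@@H]2c1cccc(C)c1[C@@H]3Cn1cc(-c2ccc(F)cc2)nn1`. In this assay compound 3 also gives only a limit, > 20000 nM.

Among the compounds with values here, the one paired change among the measured compounds is trifluoromethyl in place of fluoro on an aromatic carbon. The step it made is a step that the two limits leave unreadable from compound 1 to compound 2; its size cannot be read because both values sit at the limit of > 20000 nM in this assay, at which 3 of the 3 values shown sit.

Compound 3 is built on a different core. How the core of compound 3 differs from the core of compound 1 is not broken down here.

Compound 4 `C=C1C[C@]23C[C@@]1(O)CC[C@@H]2c1cccc(C)c1[C@@H]3Cn1cc(-c2ccc(C(F)(F)F)cc2)nn1` has not yet been measured in this assay. It stands to compound 3 as compound 2 stands to compound 1: the change is trifluoromethyl in place of fluoro on an aromatic carbon, the same change as before, at the same kind of place on the same kind of ring.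

Within the data shown here, for compound 3 the only information in this assay is its limit, > 20000 nM. The step from compound 3 to compound 4 is therefore expected to be a step that the limit leaves unreadable from compound 3 to compound 4, which rests on a step that the two limits leave unreadable from compound 1 to compound 2 being unreadable and on all values sitting at the limit of > 20000 nM in this assay, at which 3 of the 3 values shown sit. Compound 4 is estimated at 30000 nM, with a range from 15000 nM to 100000 nM, and is expected most likely to be reported again as a limit rather than a number.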

Compound 4, half-maximal inhibitory concentration: > 20000 nM
Compound 4: only a limit was reported; the forecaster's own chance of this, stated with the estimate: 85%; the middle value is on the limit's open side.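

In this assay the values of compound 3 and compound 4 are both limits and not numbers, so the change from fluoro to trifluoromethyl between them gives no readable step, and all four compounds share one limit: the limit of > 20000 nM in this assay, at which 4 of the 4 values shown sit. The compounds shown leave open what concentration of any of the four would reach half-maximal inhibition, and whether the core or the aryl group alters it.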